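Swapping a hydroxyethyl linker for an ethenyl linker

A few compounds are considered here, and "the series" means these few. Any claim that something is new, unique, unknown or untested is made for them only; others in the source may bear on it.

Compound 1 `C=C1[C@H](O)C[C@H]2C(C)(C)CCC[C@]2(C)[C@H]1/C=C/c1ccoc1` gives 3.12 ug/mL in a functional assay on HUVEC cells (Homo sapiens) for inhibition, read by colorimetric assay and MTT assay; on this read-out higher numbers stand for weaker inhibition and lower numbers for stronger inhibition.
Compound 2 `C=C1[C@@H](O[Si](C)(C)C(C)(C)C)C[C@H]2C(C)(C)CCC[C@]2(C)[C@H]1C[C@H](O)c1ccoc1` gives 7.71 ug/mL in this assay.
Compound 3 `C=C1[C@@H](O)C[C@H]2C(C)(C)CCC[C@]2(C)[C@H]1C[C@H](O)c1ccoc1` gives 29.7 ug/mL in this assay.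

Compound 2 holds the second highest of the three numbers in this assay: compound 1 sits below it and compound 3 above it. Among the measured compounds shown here, the one measured step that changes a single feature is a 3.9-fold higher number from compound 2 to compound 3 (0.59 log units; beyond the scatter), which shows that removing the silyl group from the oxygen on the saturated carbon weakens inhibition.

Compound 4 `C=C1[C@@H](O[Si](C)(C)C(C)(C)C)C[C@H]2C(C)(C)CCC[C@]2(C)[C@H]1/C=C/c1ccoc1` keeps the silyl ether of compound 2 and changes only the linker to the furan ring: 2-(furan-3-yl)ethenyl in place of 2-(furan-3-yl)-2-hydroxyethyl on a saturated ring carbon. For the measured compounds named here, no measured step isolates this exact change. The closest comparison is between compound 3 and compound 1, which share a free hydroxyl and differ in the linker and in one stereocentre; compound 1 gives 3.12 ug/mL, well below compound 3 at 29.7 ug/mL. If the ethenyl linker behaves similarly on the silyl-protected core, a step of a 5.1-fold lower number from compound 2 to compound 4 (0.71 log units; beyond the scatter) is expected, giving stronger inhibition. Compound 4 is therefore estimated at 1.5 ug/mL, within a range of 0.4 ug/mL to 5 ug/mL in this assay.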

Compound 4, half-maximal inhibitory concentration: > 50 ug/mL
Compound 4 was reported as a limit; the forecaster's own chance of this, stated with the estimate: 5%; middle value at least 33-fold (1.52 log units) from the limit.
By their numbers in this assay, from the lowest: compound 1; then compound 2; then compound 3. At a limit, above all of these: compound 4.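

Compound 4 carries a limit and not a number: the limit of > 50 ug/mL in this assay, at which 1 of the 4 values shown sits. Setting 2-(furan-3-yl)ethenyl in place of 2-(furan-3-yl)-2-hydroxyethyl on this saturated ring carbon gives an at least 6.4-fold higher number from compound 2 to compound 4 (0.81 log units; beyond the scatter), so with the silyl ether in place, the change weakens inhibition in this assay. Among the compounds shown here, until now the only step that changed a single feature concerned the silyl group on the oxygen, whereas this one changes the linker alone and shows that the ethenyl linker does not by itself bring stronger inhibition on this core.

Compound 1 carries the same ethenyl linker with a free hydroxyl and a different stereocentre, so it differs from compound 4 in more than one place, and the compounds shown cannot tell which feature goes with compound 1 giving 3.12 ug/mL in this assay. Also open, on these data alone, are the true size of the step, which the limit leaves unfixed, and how this position would read with a plain ethyl linker, or with an amine where the linker now carries its hydroxyl.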